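A Dichlorophenyl Ring Without the Hydroxy Group

A few compounds are considered here, and "the series" means these few. Any claim that something is new, unique, unknown or untested is made for them only; others in the source may bear on it.

Compound 1 `COc1ccc(/C=N/NC(=O)CSc2nnc(-c3ccncc3)o2)cc1` gives 15800 nM
Compound 2 `O=C(CSc1nnc(-c2ccncc2)o1)N/N=C/c1cc(Cl)ccc1O` gives 3970 nM
Compound 3 `O=C(CSc1nnc(-c2ccncc2)o1)N/N=C/c1cc(Cl)cc(Cl)c1O` gives 3260 nM

In a functional assay on HepG2 cells (Homo sapiens) for cytotoxicity, read by MTT assay, with a stated time of 48 h (a higher number here means a weaker inhibitor, a lower number a stronger inhibitor), compound 3 sits level with compound 2 and well under compound 1. Compound 4 `O=C(CSc1nnc(-c2ccncc2)o1)N/N=C/c1ccc(Cl)cc1Cl` differs from compound 3 in one place: 2,4-dichlorophenyl in place of 3,5-dichloro-2-hydroxyphenyl on a carbon with a double bond to nitrogen. For the measured compounds named here, two measured steps bear on this. Adding a chloro group changed little, a 1.2-fold lower number from compound 2 to compound 3 (0.09 log units; within the scatter). A larger, though still modest, step separates the two ends of the series, a 4.8-fold lower number from compound 1 to compound 3 (0.69 log units; beyond the scatter), and compound 1 lacks the hydroxy group, as compound 4 will. Compound 4 keeps two chloro groups, so only a small step towards a higher number is expected, a 1.8-fold higher number from compound 3 to compound 4 (0.26 log units; within the scatter). For compound 4 the estimated value is 6000 nM, with an expected range of 2000 nM to 16000 nM.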

Compound 4, half-maximal inhibitory concentration: 18600 nM
Estimate against measurement, compound 4: 3.1-fold (0.49 log units) below; the whole stated range lies below it.
By their numbers in this assay, from the lowest: compounds 3 and 2 (each within the scatter of the next); then compounds 1 and 4 (each within the scatter of the next).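

In this assay two chloro groups do not by themselves keep the number low: 2,4-dichlorophenyl gives a 5.7-fold higher number from compound 3 to compound 4 (0.76 log units; beyond the scatter) and also a 4.7-fold higher number from compound 2 to compound 4 (0.67 log units; beyond the scatter). Compound 4 instead stands level with the methoxy compound, with a 1.2-fold higher number from compound 1 to compound 4 (0.07 log units; within the scatter). Among these compounds, only compound 2 and compound 3 carry the hydroxy group and only they have the lower numbers, though no available measurement explains this. The chloro groups also sit differently in compound 4, so the hydroxy group's own contribution remains unseparated. An amine in its place could show whether that particular group matters.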